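This account rests on a few compounds, and the source may have more. Where it says the series, first, only, none or still open, it means among the compounds named here.

Working notes on the series. The shared core of compound 1 `O=C(/C=C/c1ccc(O)c(O)c1)c1ccc(O)cc1` is an enone bridge between a catechol-bearing ring and a second six-membered aromatic ring of carbon only. Among the measured compounds shown here, in an assay on RBL-1 cells for inhibition of Polyunsaturated fatty acid 5-lipoxygenase (Rattus norvegicus) (on this read-out higher numbers stand for weaker inhibition and lower numbers for stronger inhibition), compound 1 gives 4 nM, the lowest of the two numbers measured so far. Compound 2 `O=C(/C=C/c1ccc(O)c(O)c1)c1ccccc1-c1cccnc1` carries a pyridyl group on the second ring in place of the hydroxy of compound 1 and differs from compound 1 in more than one place; in this assay compound 2 gives 210 nM, a much higher number than compound 1, beyond the scatter.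

Compound 3 `O=C(/C=C/c1ccc(O)c(O)c1)c1ccc([N+](=O)[O-])cc1` has not been measured in this assay. Compared with compound 1 the change is nitro in place of hydroxy on an aromatic carbon: a nitro in place of a hydroxy on an aromatic carbon, para to a large group. For the measured compounds named here, no step between measured compounds isolates this change, so the direction must be judged from compound 1 alone. The expected step of a 3.8-fold higher number from compound 1 to compound 3 (0.57 log units; beyond the scatter) is a moderate weakening, somewhat beyond the scatter. For compound 3 the estimate in this assay is 15 nM, expected to fall between 4 nM and 60 nM.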

Compound 3, half-maximal inhibitory concentration: 23 nM
Compound 3: middle estimate off by 1.5-fold (0.19 log units), on the low side, within the range that was stated.
By their numbers in this assay, from the lowest: compound 1; then compound 3; then compound 2.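

In this assay, among the compounds shown here, the change of hydroxy to nitro on an aromatic carbon, para to a large group, gives a 5.8-fold higher number from compound 1 to compound 3 (0.76 log units; beyond the scatter) and is the first step that isolates a single change, a modest one in size. A hydroxy at this position is therefore not required for a number as low as that of compound 3 at 23 nM in this assay, even though the entering nitro has 0 hydrogen-bond donors against 1 for the hydroxy, yet the exchange is not neutral on this read-out. No measurement at hand accounts for the size or direction of this step, and a single pair cannot separate the loss of the hydroxy from the arrival of the nitro.

Open, on these data alone, is where an amine, a methoxy or a carboxylic acid at this same position would fall relative to hydroxy and nitro, which would show whether the step follows the group entering or only the hydroxy leaving. Also open, as far as these compounds go, is whether a methoxy in place of either hydroxy on the catechol-bearing ring changes the number on the same scale as the change on the second ring.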